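A few compounds are considered here, and "the series" means these few. Any claim that something is new, unique, unknown or untested is made for them only; others in the source may bear on it.

Measured compounds:
compound 1, `COc1cc(C(=O)c2sc(-c3cccs3)cc2N)cc(OC)c1OC`, 1.7 nM in a functional assay on FM3A cells (Mus musculus) for antiproliferative activity; on this read-out lower numbers stand for stronger inhibition and higher numbers for weaker inhibition
compound 2, `COc1cc(C(=O)c2sc(-c3ccc(Cl)c(Cl)c3)cc2N)cc(OC)c1OC`, 400 nM
compound 3, `COc1cc(C(=O)c2sc(-c3ccsc3)cc2N)cc(OC)c1OC`, 3.7 nM

Compound 3 stands second highest of the three numbers in this assay, close to one neighbour, with a 2.2-fold higher number from compound 1 to compound 3 (0.34 log units; beyond the scatter), and far from the other, with a 110-fold lower number from compound 2 to compound 3 (2.03 log units; beyond the scatter). Compound 4, `COc1ccc(-c2cc(N)c(C(=O)c3cc(OC)c(OC)c(OC)c3)s2)cc1`, differs from compound 3 in one place: 4-methoxyphenyl in place of thiophen-3-yl on an aromatic carbon. Within the data shown here, two measured steps bear on this change. Replacing a thiophene ring by a six-membered carbon ring raised the number sharply in a 240-fold higher number from compound 1 to compound 2 (2.37 log units; beyond the scatter) and a 110-fold lower number from compound 2 to compound 3 (2.03 log units; beyond the scatter), but that ring carried two chlorines, not a methoxy group, so the size of the step is uncertain. A higher number beyond the scatter is expected. Compound 4 is therefore expected to give 20 nM, with a range of 3 nM to 150 nM, that is a 5.4-fold higher number from compound 3 to compound 4 (0.73 log units; beyond the scatter).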

Compound 4, half-maximal inhibitory concentration: 31 nM
For compound 4 the middle estimate is 1.6-fold (0.19 log units) below the measured one, and the stated range covers the measured number.
By their numbers in this assay, from the lowest: compound 1; then compound 3; then compound 4; then compound 2.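

In this assay, a six-membered carbon ring at this position need not cost as much as compound 2 suggested: the 4-methoxyphenyl group recovers much of the loss (a 13-fold lower number from compound 2 to compound 4 (1.11 log units; beyond the scatter)). It still falls short of both thiophene rings (an 8.4-fold higher number from compound 3 to compound 4 (0.92 log units; beyond the scatter); an 18-fold higher number from compound 1 to compound 4 (1.26 log units; beyond the scatter)), so among these four compounds the outcome depends on both the ring and what it carries. Nothing given here accounts for these differences. The compounds shown leave open where an unsubstituted phenyl would fall, and whether a dimethylamino group or a carboxylic acid in place of the methoxy group would move the number further.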